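From 3-chlorophenyl to 2-chlorophenyl in compound 3

This account rests on a few compounds, and the source may have more. Where it says the series, first, only, none or still open, it means among the compounds named here.

In an ADME assay on L132 cells (Homo sapiens) for cytotoxicity, read by MTT assay, with a stated time of 48 h (on this read-out higher numbers stand for weaker inhibition and lower numbers for stronger inhibition), compound 1 `C/C(=C\CC/C(C)=C/CC[C@@H]1[C@@]2(C)CCC(=O)C(C)(C)[C@H]2CC[C@@]1(C)O)CC/C=C(\C)C(=O)OCc1cn(-c2ccc(F)c(Cl)c2)nn1` gives > 150000 nM, which is a limit of the assay and not a number. Within the data shown here, compound 2 `C/C(=C\CC/C(C)=C/CC[C@@H]1[C@@]2(C)CCC(=O)C(C)(C)[C@H]2CC[C@@]1(C)O)CC/C=C(\C)C(=O)OCc1cn(-c2cccc(Cl)c2)nn1` gives 94200 nM, the only actual number available, so it has no measured neighbour to be ranked against. Compound 3 `C/C(=C\CC/C(C)=C/CC[C@@H]1[C@@]2(C)CCC(=O)C(C)(C)[C@H]2CC[C@@]1(C)O)CC/C=C(\C)C(=O)OCc1cn(-c2ccccc2Cl)nn1` has the same atoms as compound 2, joined differently: 2-chlorophenyl in place of 3-chlorophenyl on an aromatic nitrogen. In short, it carries 2-chlorophenyl in place of 3-chlorophenyl on an aromatic nitrogen.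

Among the measured compounds shown here, only one measured step bears on this change, and only indirectly. That step, an at least 1.5-fold lower number from compound 1 to compound 2 (0.20 log units; that floor lies within the scatter), comes with hydrogen in place of fluoro on an aromatic carbon, and it rests on (the limit of > 150000 nM in this assay, at which 1 of the 2 values shown sits). It shows a change on the same aryl group that cannot be told from the scatter, but it does not move the chlorine, so it offers no measured size for the new change. As far as these compounds go, no step beyond the scatter is therefore expected, and the direction remains open. The expected change is a 1.1-fold higher number from compound 2 to compound 3 (0.03 log units; within the scatter). For compound 3 the estimated value in this assay is 100000 nM, with an expected range of 50000 nM to 200000 nM.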

Compound 3, half-maximal inhibitory concentration: > 150000 nM
Compound 3: a limit, no number; the forecaster's own chance of this, stated with the estimate: 30%; at least 1.5-fold (0.17 log units) between middle value and limit.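

In this assay, among these compounds, moving the chlorine from 3-chlorophenyl to 2-chlorophenyl gives the first step in which the chlorine itself changes place on the aryl group: an at least 1.5-fold higher number from compound 2 to compound 3 (0.20 log units; that floor lies within the scatter). This step is only a floor and does not go beyond the scatter, so it sets no size for the change and does not establish that the position of the chlorine matters, and the steps between compounds that both sit at the limit cannot be read. The series now has a single number, held by compound 2, with both of its measured neighbours resting on the same limit: the limit of > 150000 nM in this assay, at which 2 of the 3 values shown sit.

Still open, as far as these compounds go, is whether any group on this aromatic nitrogen can move the number beyond the scatter, as a plain phenyl, a 2-methoxyphenyl or a phenyl bearing an amine or a carboxylic acid in place of the chlorine might show. Also open, from the compounds shown here alone, is how much the 1-(3-chlorophenyl)-1H-1,2,3-triazol-4-yl part contributes at all, a question that a compound with a simple methyl group on that nitrogen could address.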